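Trimming One Carbon from the Pentyl Chain

The source may hold more compounds than are shown below. What is called first, only, known or untested is meant among the compounds shown, and "the series" means these compounds.

Compound 1 `C#CC(=O)N1C(CCCCC)SC[C@@H]1C(=O)OCC`: 1800 nM
Compound 2 `C#CC(=O)N1C(c2ccccc2F)SC[C@@H]1C(=O)OCC`: 1700 nM

For the measured compounds named here, in a functional assay on Huh-7 cells (Homo sapiens) for inhibition, read by sulforhodamine B assay (on this read-out lower numbers stand for stronger inhibition and higher numbers for weaker inhibition), compound 1 gives 1800 nM and compound 2 gives 1700 nM; the two sit within the scatter of each other, the only comparison available: a 1.1-fold lower number from compound 1 to compound 2 (0.02 log units; within the scatter). Compound 3 `C#CC(=O)N1C(CCCC)SC[C@@H]1C(=O)OCC` differs from compound 1 by hydrogen in place of methyl on a saturated chain carbon, four bonds along the chain from a saturated ring carbon. Going by the values given here, the single measured step replaces the whole pentyl with 2-fluorophenyl, a far larger change than removing one methyl, and it stayed within the scatter, so it bears only loosely on this step. No change beyond the scatter is therefore expected in this assay. Compound 3 is expected at 1800 nM, between 900 nM and 3600 nM. This means an expected no change at the digits printed from compound 1 to compound 3 (within the scatter).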

Compound 3, half-maximal inhibitory concentration: 500 nM
Beside the measured number, compound 3's estimate is 3.6-fold (0.56 log units) above it; the whole stated range lies above it.
By their numbers in this assay, from the lowest: compound 3; then compounds 2 and 1 (each within the scatter of the next).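

In this assay, removing the methyl four bonds along the chain from a saturated ring carbon gives a 3.6-fold lower number from compound 1 to compound 3 (0.56 log units; beyond the scatter), so this small change at the chain's far end counts for more than the earlier swap of pentyl for 2-fluorophenyl suggested. Butyl on the saturated ring carbon also compares well with 2-fluorophenyl, giving a 3.4-fold lower number from compound 2 to compound 3 (0.53 log units; beyond the scatter). Nothing available explains these differences. Going by these compounds, whether propyl or ethyl would lower the number further remains open. So does the effect of a butyl chain ending in an amine or a carboxylic acid.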